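Uronamide nitrogen substituent in the adenosine series

The source may hold more compounds than are shown below. What is called first, only, known or untested is meant among the compounds shown, and "the series" means these compounds.

Compound 1 `O=C(NC1CC1)[C@H]1O[C@@H](n2cnc3c(NCc4cccc(I)c4)nc(Cl)nc32)[C@H](O)[C@@H]1O` and compound 2 `O=C(NC1CCC1)[C@H]1O[C@@H](n2cnc3c(NCc4cccc(I)c4)nc(Cl)nc32)[C@H](O)[C@@H]1O` share the same core and differ only at the amide-type nitrogen. In an assay on CHO cells for displacement of a labelled ligand from adenosine receptor A3 (Homo sapiens) (on this read-out lower numbers stand for stronger inhibition and higher numbers for weaker inhibition), compound 1 gives 2.95 nM. In this assay, among the compounds with values here, compound 2 gives 18.2 nM, the higher of the two numbers recorded so far; its one neighbour is compound 1, and the step of a 6.2-fold higher number from compound 1 to compound 2 (0.79 log units; beyond the scatter) was cyclobutyl in place of cyclopropyl on the amide-type nitrogen. Compound 3 `O=C(NCc1cccc(Cl)c1)[C@H]1O[C@@H](n2cnc3c(NCc4cccc(I)c4)nc(Cl)nc32)[C@H](O)[C@@H]1O` carries the change (3-chlorobenzyl in place of cyclobutyl on an amide-type nitrogen). Within the data shown here, the only step that bears on it is a 6.2-fold higher number from compound 1 to compound 2 (0.79 log units; beyond the scatter), where the ring on the amide-type nitrogen grew by one carbon and the number rose beyond the scatter. The change to compound 3 introduces a group that is larger again, and it replaces a non-aromatic ring with an aromatic one. Because of the direction of a 6.2-fold higher number from compound 1 to compound 2 (0.79 log units; beyond the scatter) a further rise in this assay is expected, though the size of the move is uncertain, since no benzyl amide has been measured here. For compound 3 the expected step is a 6.6-fold higher number from compound 2 to compound 3 (0.82 log units; beyond the scatter). Compound 3 is estimated at 120 nM, within 25 nM to 600 nM.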

Compound 3, inhibition constant: 309 nM
Compound 3: the middle estimate sits 2.6-fold (0.41 log units) below what was measured, within the range that was stated.
By their numbers in this assay, from the lowest: compound 1; then compound 2; then compound 3.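

In this assay, the step from cyclobutyl to 3-chlorobenzyl on the amide-type nitrogen is a 17-fold higher number from compound 2 to compound 3 (1.23 log units; beyond the scatter), graded large where the earlier ring growth was modest, so this position does not merely drift upward as the group changes. Over the full set, the span is a 100-fold higher number from compound 1 to compound 3 (2.02 log units; beyond the scatter), and the numbers rise in the order cyclopropyl, cyclobutyl, 3-chlorobenzyl, with none of the three compounds going against that order. No measurement accounts for the rise at this position.

This single change brings in an aromatic ring, a chlorine and a larger group at once, so the compounds shown do not separate their contributions, and an unsubstituted benzyl or a 3-methylbenzyl on the same nitrogen would bear directly on that. Going by these compounds, the trend is also open at its small end and in between, where a methyl, an ethyl or a cyclopentyl group on this nitrogen would show whether the numbers keep following this order.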